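The source may report more compounds than this note shows. Statements on the series, on what has been measured and on what is new or still open speak of the compounds shown alone.

Measured so far in an ADME assay on HEK293 cells (Homo sapiens) for cytotoxicity, read by MTT assay, with a stated time of 48 h; on this read-out lower numbers stand for stronger inhibition and higher numbers for weaker inhibition:

compound 1 `CS(=O)(=O)Nc1ccc(NC(=O)c2ccc(Cl)cc2)cc1F`: 216000 nM
compound 2 `CS(=O)(=O)Nc1ccc(NC(=O)c2ccc(Cl)c([N+](=O)[O-])c2)cc1F`: 23100 nM
compound 3 `O=C(Nc1ccc(NS(=O)(=O)C(F)(F)F)c(F)c1)c1ccc(Cl)cc1`: 79000 nM

Compound 4 `O=C(Nc1ccc(NS(=O)(=O)C(F)(F)F)c(F)c1)c1ccc(Cl)c([N+](=O)[O-])c1` is not yet measured. The change from compound 3 to compound 4 is nitro in place of hydrogen on an aromatic carbon. The same change has been made once before, from compound 1 to compound 2, as nitro in place of hydrogen on an aromatic carbon, where it gave a 9.4-fold lower number from compound 1 to compound 2 (0.97 log units; beyond the scatter). The two cores differ by trifluoromethyl in place of methyl on a sulfonyl sulfur, a change that on its own gave a 2.7-fold lower number from compound 1 to compound 3 (0.44 log units; beyond the scatter). Among the measured compounds compound 3 carries the second highest number and compound 2 the lowest.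

Going by the values given here, for compound 4 in this assay a step of similar size is expected, a 7.9-fold lower number from compound 3 to compound 4 (0.90 log units; beyond the scatter), resting only on the one earlier step of a 9.4-fold lower number from compound 1 to compound 2 (0.97 log units; beyond the scatter). Compound 4 is accordingly estimated at 10000 nM, with a range from 3000 nM to 30000 nM. With a single prior example the expectation is tentative.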

Compound 4, half-maximal inhibitory concentration: 194000 nM
For compound 4 the middle estimate is 19-fold (1.29 log units) below the measured one; measured number above the stated range.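

In this assay, nitro in place of hydrogen on an aromatic carbon does not carry over from the core of compound 1 to the core of compound 3, giving a 2.5-fold higher number from compound 3 to compound 4 (0.39 log units; beyond the scatter), opposite in direction to the earlier step: the same change on two cores in this assay, a 9.4-fold lower number (0.97 log units; beyond the scatter) from compound 1 to compound 2 and a 2.5-fold higher number (0.39 log units; beyond the scatter) from compound 3 to compound 4, 23-fold (1.36 log units) apart, beyond the scatter of two such steps. Read the other way, trifluoromethyl in place of methyl on a sulfonyl sulfur also depends on the core, giving an 8.4-fold higher number from compound 2 to compound 4 (0.92 log units; beyond the scatter) when nitro is present: the same change on two cores in this assay, a 2.7-fold lower number (0.44 log units; beyond the scatter) from compound 1 to compound 3 and an 8.4-fold higher number (0.92 log units; beyond the scatter) from compound 2 to compound 4, 23-fold (1.36 log units) apart, beyond the scatter of two such steps. The two changes therefore do not add up across these compounds, but this single set of four shows neither why nor how general this is.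

From the compounds shown here alone, it remains open whether a nitrile or an amine in place of the nitro would show the same dependence on the sulfonyl substituent. The same question stands for an ethyl group in place of the trifluoromethyl.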